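The source may hold more compounds than are shown below. What is called first, only, known or untested is meant among the compounds shown, and "the series" means these compounds.

Compound 2, `CCCCCCCCCCCC[C@@H](O)[C@H]1CC[C@H]([C@H](O)CCCCCCCCCCNC(=O)c2cccs2)O1`, gives 1410 nM in a functional assay on SF-295 cells (Homo sapiens) for inhibition, read by colorimetric assay and sulforhodamine B assay, with a stated time of 48 h (a higher number here means a weaker inhibitor of growth, a lower number a stronger inhibitor of growth), and so stands lowest of the two numbers measured. Compound 1, `CCCCCCCCCCCC[C@@H](O)[C@H]1CC[C@H]([C@H](O)CCCCCCCCCCNC(=O)c2ccnn2C)O1`, gives 10000 nM in this assay. Going by the values given here, the single measured step, a 7.1-fold lower number from compound 1 to compound 2 (0.85 log units; beyond the scatter), shows that the group on the carbonyl carbon can move the read-out well beyond the scatter. Compound 3, `CCCCCCCCCCCC[C@@H](O)[C@H]1CC[C@H]([C@H](O)CCCCCCCCCCNC(=O)c2ccco2)O1`, carries the change (furan-2-yl in place of thiophen-2-yl on a carbonyl carbon). Among the compounds with values here, no measured step covers this pair of groups; the one recorded step concerns a different exchange at the same place, and the two groups counted in the difference are close analogues, each one five-membered aromatic ring with one hetero atom. The author therefore expects the step of a 1.4-fold higher number from compound 2 to compound 3 (0.15 log units; within the scatter) to be small, if anything a slight move toward a higher number, and not clearly beyond the scatter. Compound 3 is estimated at 2000 nM in this assay, with a range from 800 nM to 5000 nM.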

Compound 3, concentration for 50% growth inhibition: 33900 nM
For compound 3 the middle estimate is 17-fold (1.23 log units) below the measured one, and the stated range ends below it.
By their numbers in this assay, from the lowest: compound 2; then compound 1; then compound 3.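

In this assay, exchanging thiophen-2-yl for furan-2-yl on the carbonyl carbon gives a 24-fold higher number from compound 2 to compound 3 (1.38 log units; beyond the scatter), so two groups that differ only in the hetero atom of the ring, sulfur or oxygen, are far from interchangeable at this place. Furan-2-yl also stands above 1-methyl-1H-pyrazol-5-yl, with a 3.4-fold higher number from compound 1 to compound 3 (0.53 log units; beyond the scatter), so among these three groups thiophen-2-yl gives the lowest number, 1-methyl-1H-pyrazol-5-yl the next and furan-2-yl the highest. Nothing available accounts for the gap between the sulfur and oxygen rings.

The compounds shown leave open whether any other group on this carbonyl carbon, such as phenyl or pyridin-2-yl, would match or pass thiophen-2-yl. They also leave open whether the same exchange would give a step of similar size with a shorter chain between the amide nitrogen and the shared core.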